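This account rests on a few compounds, and the source may have more. Where it says the series, first, only, none or still open, it means among the compounds named here.

Measured compounds:
compound 1, `C#CCNC(=O)c1cccc2c1cc(C)n2-c1nc2c(c(NCc3ccccc3)n1)CCCC2`, 470 nM
compound 2, `CC#CCNC(=O)c1cccc2c1cc(C)n2-c1nc2c(c(NCc3ccccc3)n1)CCCC2`, 723 nM
compound 3, `C#CC(=O)Nc1cccc2c1cc(C)n2-c1nc2c(c(NCc3ccccc3)n1)CCCC2`, 131 nM

All three were tested in a functional assay on MIA PaCa-2 cells (Homo sapiens) for antiproliferative activity; on this read-out lower numbers stand for an effect already at smaller amounts and higher numbers for an effect only at larger amounts of compound. Compound 1 and compound 2 share a core and differ by methyl in place of hydrogen on a triple-bonded carbon, and this change gave a 1.5-fold higher number from compound 1 to compound 2 (0.19 log units; within the scatter). Compound 3 carries a different core: against compound 1 the difference is (ethynylcarbonyl)amino in place of propargylcarbamoyl on an aromatic carbon, and it gave a 3.6-fold lower number from compound 1 to compound 3 (0.55 log units; beyond the scatter). Compound 2 to compound 3 shows a 5.5-fold lower number from compound 2 to compound 3 (0.74 log units; beyond the scatter). Among the three, compound 3 has the lowest number in this assay, and its steps to both of the others lie beyond the scatter.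

Compound 4, `CC#CC(=O)Nc1cccc2c1cc(C)n2-c1nc2c(c(NCc3ccccc3)n1)CCCC2`, has not yet been measured in this assay. It stands to compound 3 as compound 2 stands to compound 1: the difference is methyl in place of hydrogen on a triple-bonded carbon. The place line reads the same in both pairs, a triple-bonded carbon whose other neighbours are a triple-bonded carbon; one bond further out the change reads ethynyl to prop-1-yn-1-yl in both, but beyond that it sits on ethynylcarbonyl in compound 3 and on propargyl in compound 1, so the surroundings are not identical.

Going by the values given here, the only guide is the measured pair, and there the step was within the scatter. Compound 4 is therefore expected to give about 200 nM in this assay, between 100 nM and 450 nM, which means a step of a 1.5-fold higher number from compound 3 to compound 4 (0.18 log units; within the scatter), resting on the small step seen from compound 1 to compound 2 and on compound 3 giving 131 nM.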

Compound 4, half-maximal effective concentration: 436 nM
For compound 4 the middle estimate is 2.2-fold (0.34 log units) below the measured one; low and high end bracket the measured number.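

In this assay, going by these compounds alone, methyl in place of hydrogen on a triple-bonded carbon gave a 3.3-fold higher number from compound 3 to compound 4 (0.52 log units; beyond the scatter), and set against the same change on the core of compound 1, the two steps do not separate: the same change on two cores in this assay, a 1.5-fold higher number (0.19 log units; within the scatter) from compound 1 to compound 2 and a 3.3-fold higher number (0.52 log units; beyond the scatter) from compound 3 to compound 4, 2.2-fold (0.34 log units) apart, within the scatter of two such steps This shows no firm difference in how the change behaves on the two cores, but it does not show that the change carries over unaltered, for each core offers only one pair, and the step is printed as within the scatter on one core and beyond it on the other. Across the cores, the methyl compound shows a 1.7-fold lower number from compound 2 to compound 4 (0.22 log units; within the scatter) and a 1.1-fold lower number from compound 1 to compound 4 (0.03 log units; within the scatter), both within the scatter, so compound 4 does not keep the clear lead of compound 3, which still has the lowest number of the four, with its steps to all the others beyond the scatter.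

The compounds shown leave open whether a longer chain such as ethyl, or a hydroxymethyl or aminomethyl group, on the triple-bonded carbon would follow the step seen with methyl. They also leave open whether the same change would give a similar step on a third core.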